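Solubility of a methoxy-for-fluoro swap on a shared core

This account rests on a few compounds, and the source may have more. Where it says the series, first, only, none or still open, it means among the compounds named here.

Of the compounds shown here, three with one shared core have been measured for how well they dissolve. Compound 1 `O[C@@H](CCc1ccc(F)cc1)C[C@@H](O)c1cc(-c2ccccc2)on1` gives 25000 nM in a physicochemical assay for solubility, in phosphate buffer, measured as kinetic solubility, at pH 7.4; on this read-out higher numbers stand for higher solubility and lower numbers for lower solubility. Compound 2 `COc1ccc(CC[C@H](O)C[C@@H](O)c2cc(-c3ccccc3)on2)cc1` carries methoxy in place of fluoro on an aromatic carbon and gives 25000 nM in this assay, so the step of no change at the digits printed from compound 1 to compound 2 (within the scatter). Compound 3 `O[C@@H](CCc1ccc(F)cc1)C[C@H](O)c1cc(-c2ccccc2)on1` differs from compound 1 only in that (the two compounds have the same atoms and bonds and differ only in configuration as drawn: 1 of 2 stereo elements differ; a stereocentre at a saturated chain carbon is drawn R in compound 1 and S in compound 3); in this assay compound 3 gives 25000 nM, and the step of no change at the digits printed from compound 1 to compound 3 (within the scatter). This rests on (the fact that compounds 1 and 3 differ only in the configuration as drawn).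

Compound 4 `COc1ccc(CC[C@H](O)C[C@H](O)c2cc(-c3ccccc3)on2)cc1` is not yet measured. Going by the values given here, it differs from compound 3 by methoxy in place of fluoro on an aromatic carbon, the same change as the one from compound 1 to compound 2, at the same place on the ring. Because that earlier step no change at the digits printed from compound 1 to compound 2 (within the scatter), the step of no change at the digits printed from compound 3 to compound 4 (within the scatter) is expected to be of a similar size. Compound 4 is therefore estimated at 25000 nM in this assay, with a likely range from 12500 nM to 50000 nM.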

Compound 4, solubility: 25000 nM
Compound 4: the middle estimate sits on the measured number at the digits printed; low and high end bracket the measured number.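

In this assay, methoxy in place of fluoro gives no change at the digits printed from compound 3 to compound 4 (within the scatter), matching the earlier no change at the digits printed from compound 1 to compound 2 (within the scatter), so the swap reads the same on these two cores. Changing the drawn stereocentre among the methoxy compounds also gives no change at the digits printed from compound 2 to compound 4 (within the scatter), and this comparison isolates configuration alone: the fact that compounds 2 and 4 differ only in the configuration as drawn. The result does not show that the swap would read the same on a core built differently; the two cores here have the same atoms and bonds, so the swap has been tested only across a change of configuration.

Compound 4 gives 25000 nM, the same value as the other three compounds, so nothing shown here tells which parts of these structures can move this read-out. As far as these compounds go, it remains open whether an amine or a carboxylic acid in place of fluoro, or a longer chain in place of the one shared here, would leave the value where it stands.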